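Methyl to isopropyl on the phenyl ring of compound 3

The source may hold more compounds than are shown below. What is called first, only, known or untested is meant among the compounds shown, and "the series" means these compounds.

Three compounds share one core and differ only in the group on the phenyl ring: compound 1 `O=C(NCc1cc(C(F)(F)F)nn1-c1cccc(Cl)c1)Nc1cccc2[nH]c(=O)ccc12` carries chloro, compound 2 `O=C(NCc1cc(C(F)(F)F)nn1-c1cccc(F)c1)Nc1cccc2[nH]c(=O)ccc12` fluoro and compound 3 `Cc1cccc(-n2nc(C(F)(F)F)cc2CNC(=O)Nc2cccc3[nH]c(=O)ccc23)c1` methyl. In an assay on HEK cells for antagonist activity at transient receptor potential cation channel subfamily V member 1 (Homo sapiens), read by FLIPR (on this read-out higher numbers stand for weaker inhibition and lower numbers for stronger inhibition), compound 1 gives 1.71 nM, compound 2 gives 1.28 nM and compound 3 gives 0.64 nM. Compound 3 has the lowest of the three numbers, yet a 2.0-fold lower number from compound 2 to compound 3 (0.30 log units; within the scatter) stays within the scatter; only a 2.7-fold lower number from compound 1 to compound 3 (0.43 log units; beyond the scatter) is a modest step beyond it, and a 1.3-fold lower number from compound 1 to compound 2 (0.13 log units; within the scatter) lies within it.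

Compound 4 `CC(C)c1cccc(-n2nc(C(F)(F)F)cc2CNC(=O)Nc2cccc3[nH]c(=O)ccc23)c1` is the next member: isopropyl in place of methyl on an aromatic carbon, the group sitting on an aromatic carbon of a six-membered aromatic ring of carbon only, meta to a large group. Within the data shown here, no measured step exchanges methyl for a larger alkyl, so the expectation rests on the three small steps at this position, of which only one exceeds the scatter. The expected step is a 1.3-fold higher number from compound 3 to compound 4 (0.10 log units; within the scatter), small and without a sure direction beyond the scatter. Compound 4 is estimated at 0.8 nM, within a range of 0.3 nM to 2.5 nM.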

Compound 4, half-maximal inhibitory concentration: 0.88 nM
Compound 4: middle estimate off by 1.1-fold (0.04 log units), on the low side; low and high end bracket the measured number.
By their numbers in this assay, from the lowest: compounds 3, 4, 2 and 1 (each within the scatter of the next, the first and the last beyond it).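

In this assay, the first alkyl enlargement at this place, on an aromatic carbon meta to a large group, is a 1.4-fold higher number from compound 3 to compound 4 (0.14 log units; within the scatter), so going from 3-methylphenyl to 3-isopropylphenyl moves the number by no more than the scatter. Against the halogens, a 1.5-fold lower number from compound 2 to compound 4 (0.16 log units; within the scatter) and a 1.9-fold lower number from compound 1 to compound 4 (0.29 log units; within the scatter) also stay within the scatter, whereas methyl alone, with a 2.7-fold lower number from compound 1 to compound 3 (0.43 log units; beyond the scatter), stands beyond it against chloro, so all the groups shown here lie close together and isopropyl does not separate from either halogen. Nothing available explains why these steps are so small.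

The compounds shown hold only chloro, fluoro, methyl and isopropyl at this place, so an amine, a carboxylic acid or a methoxy group remains open. Going by these compounds, whether a tert-butyl group or a longer chain would give a step beyond the scatter also remains open.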